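The source may hold more compounds than are shown below. What is called first, only, known or untested is meant among the compounds shown, and "the series" means these compounds.

Measured in an ADME assay on a cell-free system (plasma, Homo sapiens) for metabolic stability; a lower number here means that the compound disappears faster, a higher number that the compound lasts longer:
- compound 1 `CCN(CC)C(=O)COC(=O)[C@H](C)c1ccc(-c2ccccc2)c(F)c1`: 0.025 h
- compound 2 `Cc1nccn1CCOC(=O)[C@H](C)c1ccc(-c2ccccc2)c(F)c1`: 0.633 h
- compound 3 `Cc1nccn1CCOC(=O)[C@@H](C)c1ccc(-c2ccccc2)c(F)c1`: 5.92 h

Compound 3 holds the highest number of the three in this assay; compound 2 is nearest to it and compound 1 furthest. Two steps are known. Within the same ester group, compounds 2 and 3 differ only in configuration, and the step runs a 9.4-fold higher number from compound 2 to compound 3 (0.97 log units; beyond the scatter); this rests on (the fact that compounds 2 and 3 differ only in the configuration as drawn). Within the same configuration, the change of ester group gave a 25-fold higher number from compound 1 to compound 2 (1.40 log units; beyond the scatter).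

Compound 4 `CCN(CC)C(=O)COC(=O)[C@@H](C)c1ccc(-c2ccccc2)c(F)c1` is the next compound. It differs from compound 3 by diethylcarbamoyl in place of (2-methyl-1H-imidazol-1-yl)methyl on a saturated chain carbon bound to an oxygen next to a carbonyl group. This is the exact reverse of the change from compound 1 to compound 2, carried out on the other configuration. The step from compound 1 to compound 2 was large and beyond the scatter, so for compound 4 a large step in this assay is expected, downward, with the configuration step taken as unchanged. Compound 4 is therefore expected to give about 0.24 h in this assay, within a range from 0.05 h to 1.2 h. For compound 4 the expected step reads a 25-fold lower number from compound 3 to compound 4 (1.39 log units; beyond the scatter).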

Compound 4, half-life: 0.0433 h
Compound 4: middle estimate off by 5.5-fold (0.74 log units), on the high side, and the stated range ends above it.
By their numbers in this assay, from the lowest: compounds 1 and 4 (each within the scatter of the next); then compound 2; then compound 3.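

In this assay, diethylcarbamoyl in place of (2-methyl-1H-imidazol-1-yl)methyl at this position gives a 140-fold lower number from compound 3 to compound 4 (2.14 log units; beyond the scatter), so the size of this change is not the same on the two configurations: the same change on two cores in this assay, a 25-fold higher number (1.40 log units; beyond the scatter) from compound 1 to compound 2 and a 140-fold higher number (2.14 log units; beyond the scatter) from compound 4 to compound 3, 5.4-fold (0.73 log units) apart, beyond the scatter of two such steps The configuration step also depends on the ester group, with a 9.4-fold higher number from compound 2 to compound 3 (0.97 log units; beyond the scatter) for the (2-methyl-1H-imidazol-1-yl)methyl pair. With diethylcarbamoyl, the corresponding step is a 1.7-fold higher number from compound 1 to compound 4 (0.24 log units; within the scatter), so configuration separates this pair no further than the scatter: the fact that compounds 1 and 4 differ only in the configuration as drawn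

The compounds shown do not tell which part of the (2-methyl-1H-imidazol-1-yl)methyl group goes with the high number of compound 3 or with the dependence on configuration. From the compounds shown here alone, whether a dimethylamino group or a longer chain on this saturated chain carbon would keep that dependence also remains open.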